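Small Alkyl Amide Predicted to Restore Inhibition

This account rests on a few compounds, and the source may have more. Where it says the series, first, only, none or still open, it means among the compounds named here.

Three compounds sharing one core differ only in the group attached to the carbonyl carbon of an amide. Compound 1 `Cc1cccc(Cn2c(CN3CCN(C(=O)C4CCCC4)CC3)nc3ccccc32)c1` carries a cyclopentyl there and gives 67.5% in an assay on isolated protein for inhibition of aldehyde dehydrogenase 1A1 (Homo sapiens), read by spectrophotometry, tested at 10 uM; on this read-out higher numbers stand for more inhibition at the one concentration tested (going by the name of the read-out) and lower numbers for less inhibition. Compound 2 `Cc1cccc(Cn2c(CN3CCN(C(=O)CC(C)C)CC3)nc3ccccc32)c1` carries an isobutyl and in this assay gives 71.4%; the step of a number 3.9 percentage points higher from compound 1 to compound 2 (within the scatter) lies within the usual scatter. Compound 3 `Cc1cccc(Cn2c(CN3CCN(C(=O)c4ccc(C#N)cc4)CC3)nc3ccccc32)c1` carries a 4-cyanophenyl and in this assay gives 20.8%, the lowest of the three numbers. Both steps onto it were large: a number 46.7 percentage points lower from compound 1 to compound 3 (beyond the scatter) and a number 50.6 percentage points lower from compound 2 to compound 3 (beyond the scatter).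

Compound 4 `CCC(=O)N1CCN(Cc2nc3ccccc3n2Cc2cccc(C)c2)CC1` is not yet measured. It differs from compound 3 in one place: ethyl in place of 4-cyanophenyl on a carbonyl carbon. Two earlier steps bear on this change, because both steps of a number 46.7 percentage points lower from compound 1 to compound 3 (beyond the scatter) and a number 50.6 percentage points lower from compound 2 to compound 3 (beyond the scatter) exchanged an alkyl group on that carbonyl carbon for the 4-cyanophenyl and dropped the number by a large amount. The change to compound 4 runs the other way, back to an alkyl, so a rise of a similar size is expected. Ethyl is shorter than isobutyl or cyclopentyl, and no measured compound shows how a chain of only two carbons behaves here, so the range is kept wide. The step expected is a number 39.2 percentage points higher from compound 3 to compound 4 (beyond the scatter). Compound 4 is estimated at 60%, between 35% and 80%.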

Compound 4, a percentage reported as inhibition, at one concentration (the size of the read-out at that concentration, not a potency): 85.1%
Compound 4: the middle estimate sits 25.1 percentage points below what was measured; measured number above the stated range.
By their numbers in this assay, from the lowest: compound 3; then compounds 1 and 2 (each within the scatter of the next); then compound 4.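

In this assay, ethyl on the carbonyl carbon does more than recover what the 4-cyanophenyl lost, with a number 64.3 percentage points higher from compound 3 to compound 4 (beyond the scatter). It also stands clear of both larger alkyl groups, with a number 17.6 percentage points higher from compound 1 to compound 4 (beyond the scatter) and a number 13.7 percentage points higher from compound 2 to compound 4 (beyond the scatter), so this position does not treat all alkyl groups alike, something that cyclopentyl and isobutyl alone, being within the scatter of each other, could not reveal. Nothing measured here explains why the shortest alkyl group shown gives the highest number.

The compounds shown leave open whether the number holds, rises or falls with methyl on the carbonyl carbon, and where a straight propyl chain would fall, which would show whether chain length matters or whether ethyl is a special case. They also leave open whether the low number of compound 3 belongs to the aromatic ring itself or to its nitrile, a question that a plain phenyl on the same carbonyl carbon could help to separate.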